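Removing the sugar-like group from compound 3

The source may report more compounds than this note shows. Statements on the series, on what has been measured and on what is new or still open speak of the compounds shown alone.

Measured in a functional assay on A549 cells (Homo sapiens) for inhibition, read by MTT assay, with a stated time of 72 h; on this read-out higher numbers stand for weaker inhibition and lower numbers for stronger inhibition:
- compound 1 `CNC(=O)c1cc(Oc2ccc(Nc3nccc(N4CCCC4)n3)cc2)ccn1`: 3410 nM
- compound 2 `CCN(CC)c1ccc(C(=O)Nc2ccc(Oc3ncnc4ccsc34)cc2)cc1`: 8030 nM
- compound 3 `COc1ccc(C[C@H]2C(=O)N[C@@H](C)C(=O)N(C)[C@H]3Cc4cccc(c4)Oc4cc(ccc4O[C@H]4O[C@H](CO)[C@@H](O)[C@H](O)[C@H]4O)C[C@H](C(=O)N[C@H](C)C(=O)N[C@@H](C)C(=O)N2C)N(C)C3=O)cc1`: 1340 nM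

Of these three compounds, compound 3 has the lowest number, and its distance to each of the other two lies beyond the scatter. Going by the values given here, compounds 1 and 2 are structurally unrelated to compound 3, and no two measured compounds differ in just one place. Among the compounds with values here, the measurements therefore offer no direct precedent for the next step.

That step leads to compound 4 `COc1ccc(C[C@H]2C(=O)N[C@@H](C)C(=O)N(C)[C@H]3Cc4cccc(c4)Oc4cc(ccc4O)C[C@H](C(=O)N[C@H](C)C(=O)N[C@@H](C)C(=O)N2C)N(C)C3=O)cc1`, which has hydrogen in place of 3,4,5-trihydroxy-6-(hydroxymethyl)oxan-2-yl on an oxygen on an aromatic ring. The rest of the structure is unchanged, and the oxygen remains as a hydroxy group.

Within the data shown here, with no measured pair showing this change, the expectation in this assay is a judgement and carries wide uncertainty. The group that leaves is large, and compound 3, which carries it, stands at 1340 nM. A large step toward stronger inhibition, well beyond the scatter, is expected. The expected change is a 34-fold lower number from compound 3 to compound 4 (1.53 log units; beyond the scatter). For compound 4 the estimated value is 40 nM, with an expected range from 5 nM to 300 nM.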

Compound 4, half-maximal inhibitory concentration: 20 nM
For compound 4 the middle estimate is 2.0-fold (0.30 log units) above the measured one; low and high end bracket the measured number.
By their numbers in this assay, from the lowest: compound 4; then compound 3; then compound 1; then compound 2.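

In this assay, going by these compounds alone, this is the first change that can be read as a single step: on an oxygen on an aromatic ring, 3,4,5-trihydroxy-6-(hydroxymethyl)oxan-2-yl gives way to hydrogen and leaves a hydroxy group, with a 67-fold lower number from compound 3 to compound 4 (1.83 log units; beyond the scatter) as the outcome. The step shows that the sugar-like group is not required for inhibition in these cells, and that at this position, on this structure, carrying it goes with a much weaker result than the free hydroxy group. Nothing available explains why removing it has so large an effect.

The pair leaves open whether the step reflects the loss of the large group or the presence of the free hydroxy group itself, a question that a methoxy group or an acetyl ester on the same oxygen could help to separate. It also leaves open how a smaller group on this oxygen, such as a 2-aminoethyl chain, would compare with the two ends of this step.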